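The source may hold more compounds than are shown below. What is called first, only, known or untested is meant among the compounds shown, and "the series" means these compounds.

Going by the values given here, the three compounds measured so far share one core and differ only in the group on the aromatic ring that carries bromo, chloro or phenoxy: compound 1 `Cc1ccc(S/C(=C/c2ccc(Br)cc2)C(=O)c2ccc(Cl)cc2)cc1`, compound 2 `Cc1ccc(S/C(=C/c2ccc(Cl)cc2)C(=O)c2ccc(Cl)cc2)cc1` and compound 3 `Cc1ccc(S/C(=C/c2ccc(Oc3ccccc3)cc2)C(=O)c2ccc(Cl)cc2)cc1`. In a functional assay on DU-145 cells (Homo sapiens) for inhibition, read by trypan blue exclusion, with a stated time of 96 h (a higher number here means a weaker inhibitor of growth, a lower number a stronger inhibitor of growth), compound 1 gives 25000 nM, compound 2 gives 10000 nM and compound 3 gives 10000 nM. Compound 3 thus stands level with compound 2, the two together the lowest of the three numbers; the steps of a 2.5-fold lower number from compound 1 to compound 2 (0.40 log units; beyond the scatter) and a 2.5-fold lower number from compound 1 to compound 3 (0.40 log units; beyond the scatter) are both modest, while no change at the digits printed from compound 2 to compound 3 (within the scatter) shows none.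

Compound 4 `O=C(/C(=C\c1ccc(Oc2ccccc2)cc1)SCc1ccccc1Cl)c1ccc(Cl)cc1` is not yet measured. It differs from compound 3 on the sulfur: 2-chlorobenzyl in place of 4-methylphenyl on a sulfur. Among the compounds with values here, none of the three measured steps touches the group on the sulfur; each of them changes only the aromatic ring of the other arm, so no measured step bears directly on this change, and the data give no footing for a direction.

With nothing comparable in hand, compound 4 is expected to sit near compound 3, with a step of no change at the digits printed from compound 3 to compound 4 (within the scatter) that is expected to stay within the scatter. The estimate for compound 4 in this assay is 10000 nM, with a range from 3000 nM to 40000 nM.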

Compound 4, concentration for 50% growth inhibition: 1000 nM
Estimate against measurement, compound 4: 10-fold (1.00 log units) above; measured number below the stated range.
By their numbers in this assay, from the lowest: compound 4; then compounds 2 and 3 (each within the scatter of the next); then compound 1.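

The group on the sulfur responds more strongly than anything seen so far on the other arm: in this assay, 2-chlorobenzyl in place of 4-methylphenyl gives a 10-fold lower number from compound 3 to compound 4 (1.00 log units; beyond the scatter) on the same phenoxy background, whereas the changes on the aromatic ring of the other arm gave a 2.5-fold lower number from compound 1 to compound 2 (0.40 log units; beyond the scatter) and no change at the digits printed from compound 2 to compound 3 (within the scatter) in that assay. This step changes two things at once, since a benzyl group replaces a phenyl group on the sulfur and chloro replaces methyl on the ring, so this single pair cannot assign the lower number to either change. The compounds shown hold no measurement that accounts for this step.

As far as these compounds go, it remains open whether plain benzyl, 4-methylbenzyl or a longer chain such as 2-phenylethyl on the sulfur would retain the lower number, and whether an amine on that ring would be tolerated. Also open, from the compounds shown here alone, is whether 2-chlorobenzyl on the sulfur gives a similar step when bromo or chloro replaces phenoxy on the other arm, as the steps on the two arms have been read only one at a time.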